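Isopropoxycarbonyl in Place of Pentan-3-ylcarbonyl Under a Ceiling

The compounds below may be only part of what the source reports. "The series", "measured", "known", "first", "only" and "open" are said of these compounds alone.

Compound 1 `CCC(CC)C(=O)OCOC(=O)C1=C(S[C@@H]2CN[C@H](C(=O)Nc3cccc(C(=O)O)c3)C2)[C@H](C)[C@@H]2[C@@H]([C@@H](C)O)C(=O)N12`: in an ADME assay for metabolic stability, read by LC-MS, with a stated time of 3 h, at pH 6.5, tested at 50 uM (a lower number here means that less of the compound is left, a higher number that more of the compound is left), compound 1 gives > 95%, which is a limit of the assay rather than a number.
Compound 2 `CCOC(=O)OCOC(=O)C1=C(S[C@@H]2CN[C@H](C(=O)Nc3cccc(C(=O)OCOC(=O)OCC)c3)C2)[C@H](C)[C@@H]2[C@@H]([C@@H](C)O)C(=O)N12`: in this assay compound 2 gives > 95%, also a limit.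
Compound 3 `Cc1oc(=O)oc1COC(=O)N1C[C@@H]2C[C@H]1C(=O)Nc1cccc(c1)C(=O)OC/C=C/COC(=O)C1=C(S2)[C@H](C)[C@@H]2[C@@H]([C@@H](C)O)C(=O)N12`: in this assay compound 3 gives > 95%, again a limit.

Compound 1 thus stands at the upper edge of what this assay can report, and it does not stand there alone, since (the limit of > 95% in this assay, at which 3 of the 3 values shown sit). Every value is a limit. Within the data shown here, no order among the three compounds can be read, and no step between measured compounds can be counted.

Compound 4 `CC(C)OC(=O)OCOC(=O)C1=C(S[C@@H]2CN[C@H](C(=O)Nc3cccc(C(=O)O)c3)C2)[C@H](C)[C@@H]2[C@@H]([C@@H](C)O)C(=O)N12` differs from compound 1 in one place: isopropoxy in place of pentan-3-yl on a carbonyl carbon. Read one bond further out, this is (pentan-3-yl)carbonyl to isopropoxycarbonyl, on a carbonyl carbon whose other neighbours are oxygen next to a carbonyl group.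

With all three known values sitting at the same ceiling, the step that the limit leaves unreadable from compound 1 to compound 4 is expected to be none beyond the scatter. Compound 4 is therefore estimated at 97%, within 90% to 100%, most likely reported again only as a limit.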

Compound 4, percent of the compound remaining: > 95%
Compound 4: a limit, no number; the forecaster's own chance of this, stated with the estimate: 85%; the middle value lies beyond the limit too.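

Among these compounds, compound 4 gives > 95%, which is a limit and not a number, so no step from compound 1 to compound 4 can be read: the limit of > 95% in this assay, at which 4 of the 4 values shown sit. As far as these compounds go, whether isopropoxy and pentan-3-yl on this carbonyl carbon differ at all in this assay stays open, as does any order among the four compounds.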